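The compounds below may be only part of what the source reports. "The series", "measured", "known", "first", "only" and "open" are said of these compounds alone.

Measured compounds:
compound 1 `O=C(C1CC1)N1CCN(Cc2nc3ccccc3n2Cc2cccc(F)c2)CC1` — 27.2%
compound 2 `Cc1ccc(Cn2c(CN3CCN(C(=O)C4CC4)CC3)nc3ccccc32)cc1` — 51.5%
compound 3 `O=C(C1CC1)N1CCN(Cc2nc3ccccc3n2Cc2ccc(C(F)(F)F)cc2)CC1` — 37%

In an assay on isolated protein for inhibition of aldehyde dehydrogenase 1A1 (Homo sapiens), read by spectrophotometry, tested at 10 uM (a higher number here means more inhibition at the concentration tested (going by the name of the read-out), a lower number less inhibition), compound 3 stands second highest of the three. Its nearest neighbour is compound 1, with a number 9.8 percentage points higher from compound 1 to compound 3 (within the scatter); compound 2 sits further off, with a number 14.5 percentage points lower from compound 2 to compound 3 (beyond the scatter). Compound 4 `O=C(C1CC1)N1CCN(Cc2nc3ccccc3n2CC2CCCC2)CC1` is not yet measured and differs from compound 3 in one place: cyclopentyl in place of 4-(trifluoromethyl)phenyl on a saturated chain carbon bound to an aromatic nitrogen. For the measured compounds named here, the steps so far bear on this change only loosely: a number 24.3 percentage points higher from compound 1 to compound 2 (beyond the scatter) and a number 9.8 percentage points higher from compound 1 to compound 3 (within the scatter) exchange one substituted phenyl for another at the same position, and a number 14.5 percentage points lower from compound 2 to compound 3 (beyond the scatter) exchanges trifluoromethyl for methyl; none replaces the six-membered aromatic ring with a five-membered non-aromatic ring. All three measured values lie in a fairly narrow band, so a step of a number 7 percentage points lower from compound 3 to compound 4 (within the scatter) is expected, within the scatter, with wide uncertainty. Compound 4 is estimated at 30% (range 10% to 55%).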

Compound 4, a percentage reported as inhibition, at one concentration (the size of the read-out at that concentration, not a potency): 44.5%
Estimate against measurement, compound 4: 14.5 percentage points below, and the stated range covers the measured number.
By their numbers in this assay, from the lowest: compounds 1, 3, 4 and 2 (each within the scatter of the next, the first and the last beyond it).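

In this assay, the number stays level with a non-aromatic ring on a saturated chain carbon bound to an aromatic nitrogen: cyclopentyl gives a number 7.5 percentage points higher from compound 3 to compound 4 (within the scatter) and a number 7 percentage points lower from compound 2 to compound 4 (within the scatter) so, among these compounds, the number with cyclopentyl there is level with those with a six-membered aromatic ring in compound 3 and compound 2. Cyclopentyl also separates from 3-fluorophenyl, with a number 17.3 percentage points higher from compound 1 to compound 4 (beyond the scatter) and this is the only step of the three beyond the scatter. Nothing here explains these steps. Open, on these data alone, is whether cyclohexyl or an open pentyl chain would behave like cyclopentyl. Also open, as far as these compounds go, is what an amine or a carboxylic acid on this ring would do.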